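Carbonyl substituent change, compound 2 to compound 3

A few compounds are considered here, and "the series" means these few. Any claim that something is new, unique, unknown or untested is made for them only; others in the source may bear on it.

Measured so far in this assay:
compound 1 `NNC(=O)c1c(NC(=O)NS(=O)(=O)c2ccccc2)sc2c1CCCCC2` — 30300 nM
compound 2 `O=C(Nc1sc2c(c1C(=O)NNc1ccc(Br)cc1)CCCCC2)NS(=O)(=O)c1ccccc1` — > 100000 nM
compound 3 `O=C(Nc1sc2c(c1C(=O)N1CCN(c3ccccc3)CC1)CCCCC2)NS(=O)(=O)c1ccccc1` — not yet measured

In a functional assay on cells (Leukemia cell, Homo sapiens) for inhibition, with a stated time of 48 h (on this read-out higher numbers stand for weaker inhibition of growth and lower numbers for stronger inhibition of growth), compound 1 gives 30300 nM, a weak result on its own. For compound 2 the read-out is a limit of the assay, > 100000 nM, so compound 2 stands at the top of the numbers shown with no actual number behind it; one of the two values sits at this limit (the limit of > 100000 nM in this assay, at which 1 of the 2 values shown sits). Within the data shown here, the only measured step is an at least 3.3-fold higher number from compound 1 to compound 2 (0.51 log units; beyond the scatter), a loss of growth inhibition on adding the aryl group to the amine nitrogen.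

The change to compound 3 is 4-phenylpiperazin-1-yl in place of ((4-bromophenyl)amino)amino on a carbonyl carbon. It touches the same carbonyl but replaces the whole hydrazide arm with a cyclic amine bearing a phenyl, removing both donors. The measured step concerns a different kind of change and does not bear directly on it. Given that the starting point is a limit and the parent compound 1 is itself weak, compound 3 is expected to stay weak, estimated at 90000 nM with a range of 25000 nM to 300000 nM. The expected step, an at least 1.1-fold lower number from compound 2 to compound 3 (0.04 log units; that floor lies within the scatter), is not beyond the scatter.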

Compound 3, concentration for 50% growth inhibition: > 100000 nM
Compound 3 ended at the assay's limit; the forecaster's own chance of this, stated with the estimate: 55%; at least 1.1-fold (0.04 log units) between middle value and limit.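

In this assay compound 3 gives > 100000 nM, which is a limit of the assay and not a number. With 4-phenylpiperazin-1-yl in place of aminoamino on the carbonyl carbon, the read-out shows an at least 3.3-fold higher number from compound 1 to compound 3 (0.51 log units; beyond the scatter), so growth inhibition is lost with this cyclic amine as well as with the ((4-bromophenyl)amino)amino arm, which gave an at least 3.3-fold higher number from compound 1 to compound 2 (0.51 log units; beyond the scatter); the loss on this carbonyl is therefore not confined to a hydrazide arm carrying an aryl group. The step between compound 2 and compound 3 cannot be read, so the two large arms have no order relative to each other, and further changes that weaken growth inhibition would not be resolved in this part of the series: the limit of > 100000 nM in this assay, at which 2 of the 3 values shown sit.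

Open, going by these compounds, is whether a small group on the same carbonyl carbon, such as a hydroxyl giving the carboxylic acid or a plain methylamino, would hold or improve on compound 1, which gives 30300 nM. Also open, on these data alone, is whether the loss in compound 3 goes with the phenyl or with the ring itself, which an unsubstituted piperazin-1-yl or a morpholin-4-yl would separate.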